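Methoxy to Methyl: Little Change Expected

The source may hold more compounds than are shown below. What is called first, only, known or untested is meant among the compounds shown, and "the series" means these compounds.

Within the data shown here, compound 1 `COc1ccc(-c2nn(-c3ccccc3)cc2C(=O)NC(=S)Nc2ccc(F)cc2)cc1` was tested in a functional assay on MCF7 cells (Homo sapiens) for inhibition, read by CCK-8 assay, with a stated time of 48 h (a lower number here means a stronger inhibitor, a higher number a weaker inhibitor), and gave 4990 nM, one of only two numbers measured so far. Its nearest neighbour is compound 2 `COc1ccc(-c2nn(-c3ccccc3)cc2C(=O)NC(=S)Nc2ccc(Cl)cc2)cc1`, which in this assay gives 4760 nM; the step of a 1.0-fold lower number from compound 1 to compound 2 (0.02 log units; within the scatter) replaces fluoro with chloro on an aromatic carbon, and the two values cannot be told apart. Compound 3 `Cc1ccc(-c2nn(-c3ccccc3)cc2C(=O)NC(=S)Nc2ccc(F)cc2)cc1` differs from compound 1 at another place: methyl in place of methoxy on an aromatic carbon, on a six-membered aromatic ring of carbon only, para to a large group, so that 4-methoxyphenyl becomes 4-methylphenyl. Among the measured compounds shown here, no measured step touches this ring; the one step seen, from compound 1 to compound 2, altered a different ring and stayed within the scatter. With nothing pointing in either direction, the expected step is one no larger than the scatter, a 1.0-fold higher number from compound 1 to compound 3 (0.00 log units; within the scatter). Compound 3 is therefore estimated at 5000 nM, with a likely range from 2000 nM to 12500 nM.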

Compound 3, half-maximal inhibitory concentration: 6420 nM
Compound 3: the middle estimate sits 1.3-fold (0.11 log units) below what was measured, within the range that was stated.
By their numbers in this assay, from the lowest: compounds 2, 1 and 3 (each within the scatter of the next).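

Among these compounds, replacing 4-methoxyphenyl with 4-methylphenyl gives the first look at this ring, and the step of a 1.3-fold higher number from compound 1 to compound 3 (0.11 log units; within the scatter) shows that in this assay this change does not separate the two compounds. At this position on the aromatic ring, then, a methyl group with no hydrogen-bond acceptor serves as well as a methoxy group with one, so that the acceptor is not required for a value in this range. No measurement of any property of these two groups bears on this result, and the data offer no explanation for it.

Going by these compounds, whether a different kind of group here, such as an amine, a carboxylic acid or a longer chain, would shift the number beyond the scatter remains open. So does the result of a bare hydrogen at this position.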